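The source may hold more compounds than are shown below. What is called first, only, known or untested is meant among the compounds shown, and "the series" means these compounds.

Measured in a physicochemical assay for solubility, read by HPLC, with a stated time of 24 h; a higher number here means a more soluble compound, a lower number a less soluble compound:
Compound 1 `CC(C)(C)c1[nH]cnc1/C=c1\[nH]c(=O)/c(=C/c2cccc(C(=O)N3CCCC3)c2)[nH]c1=O`: 0.454 ug/mL
Compound 2 `CC(C)(C)c1[nH]cnc1/C=c1\[nH]c(=O)/c(=C/c2cccc(C(=O)N3CCCCC3)c2)[nH]c1=O`: < 0.1 ug/mL (a limit of the assay, not a number)

Compound 2 stands at the limit of < 0.1 ug/mL in this assay, at which 1 of the 2 values shown sits, so its true position is not known. Compound 3 `CC(C)(C)c1[nH]cnc1/C=c1\[nH]c(=O)/c(=C/c2cccc(C(=O)c3cccnc3)c2)[nH]c1=O` has pyridin-3-yl in place of piperidin-1-yl on a carbonyl carbon. For the measured compounds named here, the pyridin-3-yl group has not been measured on this carbonyl carbon in any compound so far.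

Going by the values given here, only one measured step bears on this place: an at least 4.5-fold lower number from compound 1 to compound 2 (0.65 log units; beyond the scatter). There, piperidin-1-yl replaced pyrrolidin-1-yl on the same carbonyl carbon. That step shows that an exchange here can move the number beyond the scatter, but it offers only a rough guide to size for a different incoming group. Its direction does not carry over either. A step of similar modest size is expected here, tentatively upward, and compound 3 may still return only a limit.

The estimated step is an at least 2.5-fold higher number from compound 2 to compound 3 (0.39 log units; beyond the scatter). In this assay the estimate for compound 3 is 0.25 ug/mL, with an expected range of 0.07 ug/mL to 1 ug/mL.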

Compound 3, solubility: < 0.1 ug/mL
Compound 3 ended at the assay's limit; the forecaster's own chance of this, stated with the estimate: 35%; middle value at least 2.5-fold (0.39 log units) from the limit.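

With pyridin-3-yl in place of pyrrolidin-1-yl on the carbonyl carbon, this assay gives an at least 4.5-fold lower number from compound 1 to compound 3 (0.65 log units; beyond the scatter). The drop first seen with piperidin-1-yl is therefore not confined to that group: an aromatic six-membered ring and a non-aromatic one, each with one hetero atom, both end at a limit, and among the three compounds only compound 1, with pyrrolidin-1-yl, gives a value that is a number. The step between the two six-membered groups cannot be read, because the values of both compounds are limits and not numbers: the limit of < 0.1 ug/mL in this assay, at which 2 of the 3 values shown sit.

The compounds shown leave open whether compound 2 and compound 3 truly differ in this assay, and how far either lies from compound 1 beyond the least step that is printed. Also open, from the compounds shown here alone, is what a morpholin-4-yl or a 4-methylpiperazin-1-yl group on this carbonyl carbon would give, and whether any such group would return a number rather than a limit.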